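Oxolan-3-yl in place of cyclobutylmethyl: clearance notes

This account rests on a few compounds, and the source may have more. Where it says the series, first, only, none or still open, it means among the compounds named here.

Measured so far in an in vitro ADME assay on microsomes (Rattus norvegicus) for metabolic stability; on this read-out higher numbers stand for fast clearance and lower numbers for slow clearance:
compound 1 `O=C(CN(C(=O)c1ccc(-n2ccnc2)cc1)C1CCCCC1)Nc1cc(F)cc(F)c1` gives 1.2 mL.min-1.g-1
compound 2 `O=C(CN(C(=O)c1ccc(-c2ccccn2)cc1)C1CCCOC1)Nc1cc(F)cc(F)c1` gives 2 mL.min-1.g-1
compound 3 `O=C(CN(CC1CCC1)C(=O)c1ccc(-c2ccccn2)cc1)Nc1cc(F)cc(F)c1` gives 4.8 mL.min-1.g-1

Compound 3 holds the highest of the three numbers, and compound 2 and compound 1 both lie lower, beyond the scatter. Compound 4 `O=C(CN(C(=O)c1ccc(-c2ccccn2)cc1)C1CCOC1)Nc1cc(F)cc(F)c1` has not yet been measured. The change from compound 3 is oxolan-3-yl in place of cyclobutylmethyl on an amide-type nitrogen.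

Among the measured compounds shown here, the only measured step that bears on this is a 2.4-fold higher number from compound 2 to compound 3 (0.38 log units; beyond the scatter) with cyclobutylmethyl in place of oxan-3-yl at the same kind of nitrogen. That step is modest but beyond the scatter. Read in reverse, it points to a number in this assay that falls by a similar modest size when cyclobutylmethyl leaves for a ring with one hetero atom. For the measured compounds named here, compound 1 differs from compound 3 in more than one place and supplies no step. Going by the values given here, no measurement yet compares oxolan-3-yl with oxan-3-yl, so the size remains uncertain.

The expected change is a 2.4-fold lower number from compound 3 to compound 4 (0.38 log units; beyond the scatter) in this estimate. Compound 4 is estimated at 2 mL.min-1.g-1 (expected range 1 mL.min-1.g-1 to 3.8 mL.min-1.g-1).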

Compound 4, intrinsic clearance in microsomes: 3.2 mL.min-1.g-1
Beside the measured number, compound 4's estimate is 1.6-fold (0.20 log units) below it; the measured number falls inside the stated range.
By their numbers in this assay, from the lowest: compounds 1, 2, 4 and 3 (each within the scatter of the next, the first and the last beyond it).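

In this assay, oxolan-3-yl on the amide-type nitrogen gives a 1.5-fold lower number from compound 3 to compound 4 (0.18 log units; within the scatter), so this exchange for cyclobutylmethyl does not separate the two compounds. Against the six-membered ring, the same group gives a 1.6-fold higher number from compound 2 to compound 4 (0.20 log units; within the scatter), so the exchange of oxan-3-yl for oxolan-3-yl does not separate that pair either. Compound 4 therefore sits within the scatter of both neighbours, even though those neighbours remain apart in a 2.4-fold higher number from compound 2 to compound 3 (0.38 log units; beyond the scatter), which leaves that step as the only one at this position that stands beyond the scatter and shows that a single ring oxygen in the entering group does not by itself carry a step of that kind over to oxolan-3-yl.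

Still open, as far as these compounds go, is how this position reads with an amine-bearing ring such as piperidin-4-yl or with a longer open chain, and whether the cyclohexyl group of compound 1 holds its place with the shared core otherwise unchanged, since compound 1 differs from the others in more than one place. Nothing on hand explains why these steps take the sizes they do.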